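The compounds below may be only part of what the source reports. "The series", "measured", "known", "first", "only" and "open" are said of these compounds alone.

Compound 1 `CN(Cc1cccc(Cl)c1)C(=O)c1cc2c(Cc3ccccc3)n[nH]c2cc1O`: 5300 nM
Compound 2 `CN(Cc1cccc(C(F)(F)F)c1)C(=O)c1cc2c(Cc3ccccc3)n[nH]c2cc1O`: "not determined" (no result reported)
Compound 3 `CN(Cc1ccc(F)cc1)C(=O)c1cc2c(Cc3ccccc3)n[nH]c2cc1O`: not yet measured

Among the measured compounds shown here, in a functional assay on A2780 cells (Homo sapiens) for antiproliferative activity, read by resazurin assay, with a stated time of 72 h (on this read-out lower numbers stand for stronger inhibition and higher numbers for weaker inhibition), compound 2 has no single number, so its standing remains open and no step from it can be sized. The structural change is 4-fluorophenyl in place of 3-(trifluoromethyl)phenyl on a saturated chain carbon bound to an amide-type nitrogen, and the shared core stays the same. For the measured compounds named here, the only numerical anchor is compound 1 at 5300 nM. From that level, no shift beyond the scatter is expected in this assay, in either direction. For compound 3 the expected value is 6000 nM, with an estimated range of 2500 nM to 15000 nM.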

Compound 3, half-maximal inhibitory concentration: 4100 nM
Compound 3: middle estimate off by 1.5-fold (0.17 log units), on the high side; the range from low to high includes it.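

In this assay the change to 4-fluorophenyl from 3-chlorophenyl on a saturated chain carbon bound to an amide-type nitrogen gives a 1.3-fold lower number from compound 1 to compound 3 (0.11 log units; within the scatter) and so shows that this position tolerates this exchange without a shift beyond the scatter. Steps involving compound 2 cannot be read. No measurement bears on why the two values stay close. Still open, on these data alone, is the standing of 3-(trifluoromethyl)phenyl at this position. Also open, as far as these compounds go, is whether an amine or a carboxylic acid on the phenyl ring, or a longer chain in place of the single saturated carbon, would move the value beyond the scatter.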